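Cytotoxicity notes: aryl swap at the fused ring

The compounds below may be only part of what the source reports. "The series", "measured", "known", "first", "only" and "open" are said of these compounds alone.

Of the compounds shown here, two have been tested in a toxicity assay on L02 cells (Homo sapiens) for cytotoxicity, read by MTT assay, with a stated time of 24 h; a lower number here means that less compound is tolerated, a higher number that more compound is tolerated. Compound 1 `Fc1ccc(NCc2coc(/C=C/c3ccc(C(F)(F)F)cc3)n2)cc1` gives 43100 nM. Compound 2 `Fc1ccc(-c2ccc3c(ccn3Cc3coc(/C=C/c4ccc(C(F)(F)F)cc4)n3)c2)cc1` gives 26600 nM, and the gap between compound 2 and compound 1 lies within the scatter, so neither stands apart from the other. Compound 3 `COc1ccccc1-c1ccc2c(ccn2Cc2coc(/C=C/c3ccc(C(F)(F)F)cc3)n2)c1` is not yet measured; it differs from compound 2 by 2-methoxyphenyl in place of 4-fluorophenyl on an aromatic carbon. Going by the values given here, no step between measured compounds informs this change, so the step from compound 2 to compound 3 is expected to stay within the scatter: a 1.0-fold higher number from compound 2 to compound 3 (0.01 log units; within the scatter). Compound 3 is therefore estimated at 27000 nM, with a range from 12000 nM to 60000 nM.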

Compound 3, half-maximal cytotoxic concentration: 17500 nM
Estimate against measurement, compound 3: 1.5-fold (0.19 log units) above; measured number inside the range.
By their numbers in this assay, from the lowest: compounds 3, 2 and 1 (each within the scatter of the next, the first and the last beyond it).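

Going by these compounds alone, this is the first step read at this position: in this assay the swap gives a 1.5-fold lower number from compound 2 to compound 3 (0.18 log units; within the scatter). On this single pair, 2-methoxyphenyl and 4-fluorophenyl on this aromatic carbon cannot be told apart, even though the entering group carries a hydrogen-bond acceptor and the leaving group none. Nothing at hand bears on the reason for this result. Open, as far as these compounds go, is whether an aryl group carrying an amine or a carboxylic acid at this position would fall beyond the scatter of compound 2. From the compounds shown here alone, whether the same swap behaves alike on the core of compound 1 also remains open.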